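Swapping the nitrile tail of compound 3 for an allyl tail

The source may hold more compounds than are shown below. What is called first, only, known or untested is meant among the compounds shown, and "the series" means these compounds.

Measured so far in a functional assay on MCF7 cells (Homo sapiens), read by MTT assay, with a stated time of 48 h; a higher number here means a weaker inhibitor, a lower number a stronger inhibitor
Compound 1 `CCN(CC)CCNC(=O)c1ccc(C(CC)(CC)c2ccc(OCC(O)C(C)(C)C)c(C)c2)n1CC` gives 690 nM
Compound 2 `CCN(CC)CCCNC(=O)c1ccc(C(CC)(CC)c2ccc(OCC(O)C(C)(C)C)c(C)c2)n1CC` gives 190 nM
Compound 3 `CCn1c(C(=O)N(C)CCC#N)ccc1C(CC)(CC)c1ccc(OCC(O)C(C)(C)C)c(C)c1` gives > 50000 nM as a limit of the assay, not a number

Compound 3 thus has no exact number of its own. Compounds 1 and 2 carry a diethylamino chain, and its loss came with large steps (an at least 72-fold higher number from compound 1 to compound 3 (1.86 log units; beyond the scatter)) and (an at least 260-fold higher number from compound 2 to compound 3 (2.42 log units; beyond the scatter)). Lengthening that chain gave only a modest step (a 3.6-fold lower number from compound 1 to compound 2 (0.56 log units; beyond the scatter)).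

Compound 4 `C=CCN(C)C(=O)c1ccc(C(CC)(CC)c2ccc(OCC(O)C(C)(C)C)c(C)c2)n1CC` differs from compound 3 at one place vinyl in place of cyanomethyl on a saturated chain carbon bound to an amide-type nitrogen with vinyl in place of cyanomethyl on a saturated chain carbon bound to an amide-type nitrogen. Among the compounds with values here, it also lacks the diethylamino chain, and no measured step covers this exchange. In this assay no step beyond the scatter is expected (a number no higher from compound 3 to compound 4 (the limit leaves the size open)) and another limit reading is likely. Compound 4 is estimated at 50000 nM with an expected range (12000 nM to 120000 nM).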

Compound 4, half-maximal inhibitory concentration: > 50000 nM
Compound 4 gave a limit, no number; the forecaster's own chance of this, stated with the estimate: 70%; the middle value lies on the limit itself.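

A second tail without the diethylamino chain, compound 4, also ends at a limit in this assay, so reaching that limit is not tied to the nitrile. The loss of the chain again comes with large steps: an at least 260-fold higher number from compound 2 to compound 4 (2.42 log units; beyond the scatter) and an at least 72-fold higher number from compound 1 to compound 4 (1.86 log units; beyond the scatter). The step between the two tails themselves cannot be read, because compound 3 and compound 4 both sit at a limit: the limit of > 50000 nM in this assay, at which 2 of the 4 values shown sit.

Going by these compounds, whether a dimethylamino chain would give a measurable number stays open. So does whether a diethylamino chain longer than that of compound 2 would lower the number further.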